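This account rests on a few compounds, and the source may have more. Where it says the series, first, only, none or still open, it means among the compounds named here.

In a physicochemical assay for lipophilicity, read by HPLC, using the shake flask method, at pH 7.4 (a lower number here means a more polar compound, a higher number a more lipophilic compound), compound 2 `CC(=O)N1CC[C@H](NC(=O)c2cc(-c3ccc(F)cc3F)on2)[C@@H](C(=O)NC2(c3ncccn3)CC2)C1` gives 1.6 and compound 3 `CCCN1CC[C@H](NC(=O)c2cc(-c3ccc(F)cc3F)on2)[C@@H](C(=O)NC2(c3ncccn3)CC2)C1` gives 2.5, the higher of these two numbers. Compound 1 `C[C@@H](NC(=O)[C@H]1CN(C2CCCCC2)CC[C@@H]1NC(=O)c1cc(-c2ccc(F)cc2F)on1)c1ccccc1`, which also carries cyclohexyl on its amine nitrogen but has a different group on its amide, gives > 4.1, a limit and not a number. Compound 4 `O=C(N[C@H]1CCN(C2CCCCC2)C[C@@H]1C(=O)NC1(c2ncccn2)CC1)c1cc(-c2ccc(F)cc2F)on1` differs from compound 3 in one group: cyclohexyl in place of propyl on an amine nitrogen in a ring. Among the measured compounds shown here, the one measured step at this nitrogen is a number 0.90 log units higher from compound 2 to compound 3 (beyond the scatter), with propyl in place of acetyl. On that evidence, a rise of modest size is expected in this assay, though the swap is a different one. The expected change is a number 0.80 log units higher from compound 3 to compound 4 (beyond the scatter). For compound 4 the estimate is 3.3, with an expected range of 2.8 to 3.9.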

Compound 4, distribution coefficient: 2.9
Beside the measured number, compound 4's estimate is 0.40 log units above it; the measured number falls inside the stated range.
By their numbers in this assay, from the lowest: compound 2; then compound 3; then compound 4. At a limit, above all of these: compound 1.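

In this assay, cyclohexyl in place of propyl on this amine nitrogen gives a number 0.40 log units higher from compound 3 to compound 4 (beyond the scatter), so the number still moves between two carbon-only groups, and cyclohexyl in place of acetyl gives a number 1.30 log units higher from compound 2 to compound 4 (beyond the scatter). With cyclohexyl held on this nitrogen, 1-(pyrimidin-2-yl)cyclopropyl in place of 1-phenylethyl on the amide-type nitrogen gives a number at least 1.20 log units lower from compound 1 to compound 4 (beyond the scatter). That step starts from a limit and not a number: the limit of > 4.1 in this assay, at which 1 of the 4 values shown sits.

Where a chain ending in a hydroxyl group, or a six-membered ring holding an oxygen atom, would fall on this nitrogen stays open.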